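Replacing an Alkoxy Chain With an Aryl Ring

This account rests on a few compounds, and the source may have more. Where it says the series, first, only, none or still open, it means among the compounds named here.

Compound 2 `O=C(NCc1ccc(C(F)(F)F)nc1OCC1CCC1)Nc1cccc2[nH]c(=O)ccc12` gives 1.49 nM in an assay on HEK cells for antagonist activity at transient receptor potential cation channel subfamily V member 1 (Homo sapiens), read by FLIPR (on this read-out higher numbers stand for weaker inhibition and lower numbers for stronger inhibition), the lowest of the two numbers shown; compound 1 `CCCCCCOc1nc(C(F)(F)F)ccc1CNC(=O)Nc1cccc2[nH]c(=O)ccc12` gives 3.19 nM. Going by the values given here, the only measured step, a 2.1-fold lower number from compound 1 to compound 2 (0.33 log units; beyond the scatter), changes the chain on the oxygen, not the oxygen itself. Among the compounds with values here, compound 3 `O=C(NCc1ccc(C(F)(F)F)nc1-c1ccc(F)cc1)Nc1cccc2[nH]c(=O)ccc12` differs from compound 2 by 4-fluorophenyl in place of cyclobutylmethoxy on an aromatic carbon, a change no measured step matches. Without a comparable step, the size and direction are uncertain, and a modest weakening is expected as a 3.4-fold higher number from compound 2 to compound 3 (0.53 log units; beyond the scatter). Compound 3 is estimated at 5 nM, within 1 nM to 30 nM.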

Compound 3, half-maximal inhibitory concentration: 1.93 nM
Compound 3: the middle estimate sits 2.6-fold (0.41 log units) above what was measured; the measured number falls inside the stated range.
By their numbers in this assay, from the lowest: compounds 2, 3 and 1 (each within the scatter of the next, the first and the last beyond it).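

In this assay this carbon, next to the ring nitrogen, accepts a directly attached 4-fluorophenyl ring in place of an oxygen-linked chain with no shift beyond the scatter (a 1.3-fold higher number from compound 2 to compound 3 (0.11 log units; within the scatter)) and (a 1.7-fold lower number from compound 1 to compound 3 (0.22 log units; within the scatter)). The earlier compounds shown here varied only the chain on the oxygen, whereas compound 3 shows that low-nanomolar numbers do not depend on keeping that oxygen. The data offer no measured explanation for this tolerance.

Whether the fluorine contributes remains open, since the compounds shown do not include unsubstituted phenyl. On these data alone, how an amine or a carboxylic acid would fare on this carbon also remains unknown.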